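Compound 3 to compound 4: exchange on the sulfur

The source may report more compounds than this note shows. Statements on the series, on what has been measured and on what is new or still open speak of the compounds shown alone.

In an ADME assay on the whole organism (plasma) for pharmacokinetics, with Rhesus monkey (Macaca mulatta) as the target, read by LC-MS, at a dose of 1 mg/kg by the oral route (a lower number here means less compound in the circulation, a higher number more compound in the circulation at the dose given), compound 3 (`COc1ccc2nc(COc3ccc(CC(SSCC(N)C(=O)O)C(=O)O)cc3)n(C)c2c1`) gives 12.3 ng.h/mL. That number lies within the scatter of compound 1 (`COc1ccc2nc(COc3ccc(CC(SC)C(N)=O)cc3)n(C)c2c1`) at 16.9 ng.h/mL, whereas compound 2 (`COc1ccc2nc(COc3ccc(CC(C(N)=O)[S+](C)[O-])cc3)n(C)c2c1`) stands clearly higher at 36.7 ng.h/mL. Compound 4 (`COc1ccc2nc(COc3ccc(CC(SC)C(=O)O)cc3)n(C)c2c1`) carries methyl in place of (2-amino-2-carboxyethyl)sulfanyl on a sulfur.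

Going by the values given here, only one measured step involves a change on a sulfur, a 2.2-fold higher number from compound 1 to compound 2 (0.34 log units; beyond the scatter), and it is modest. That step is a different change, so it offers only a rough guide to size. Among the compounds with values here, no measured pair isolates the present exchange. Compound 1 also has methyl on the sulfur, but it differs from compound 4 elsewhere. In this assay compound 1 stands at 16.9 ng.h/mL. All three numbers lie close together, so a small rise that stays within the scatter is expected, stated as a 1.6-fold higher number from compound 3 to compound 4 (0.21 log units; within the scatter). For compound 4 an estimated 20 ng.h/mL is expected (range 6 ng.h/mL to 70 ng.h/mL).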

Compound 4, area under the concentration-time curve: 76.8 ng.h/mL
Compound 4: the middle estimate sits 3.8-fold (0.58 log units) below what was measured; measured number outside the range, above it.
By their numbers in this assay, from the lowest: compounds 3 and 1 (each within the scatter of the next); then compound 2; then compound 4.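

In this assay the exchange on the sulfur gives the largest step seen so far in the series, a 6.2-fold higher number from compound 3 to compound 4 (0.80 log units; beyond the scatter) with methyl in place of (2-amino-2-carboxyethyl)sulfanyl. The carbonyl carbon also proves to be a responsive place: hydroxy in place of amino gives a 4.5-fold higher number from compound 1 to compound 4 (0.66 log units; beyond the scatter) while methyl stays on the sulfur, and the step of a 2.1-fold higher number from compound 2 to compound 4 (0.32 log units; beyond the scatter) leaves compound 4 with the highest number of the four. No measurement at hand accounts for these steps.

Open, going by these compounds, is whether a longer chain in place of methyl on the sulfur keeps the number of compound 4. Also open, on these data alone, is how a carboxylic acid on the carbonyl carbon behaves together with the oxidised sulfur of compound 2.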